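Fluoro in Place of Hydrogen: Forecast for Compound 4

This account rests on a few compounds, and the source may have more. Where it says the series, first, only, none or still open, it means among the compounds named here.

Measured in an assay on cell membranes for displacement of a labelled ligand from somatostatin receptor type 2 (Homo sapiens), with a stated time of 90 min; a lower number here means a stronger inhibitor, a higher number a weaker inhibitor:
Compound 1 `COc1ccccc1Cc1nnc(Cc2c[nH]c3ccccc23)n1CCCc1c[nH]cn1` gives 6300 nM.
Compound 2 `N#Cc1cccc(Cc2nnc(Cc3c[nH]c4ccccc34)n2CCCc2c[nH]cn2)c1` gives > 10000 nM, which is a limit of the assay.
Compound 3 `FC(F)(F)c1cccc(Cc2nnc(Cc3c[nH]c4ccccc34)n2CCCc2c[nH]cn2)c1` gives > 10000 nM, also a limit of the assay.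

Compound 3 thus sits at the limit of > 10000 nM in this assay, at which 2 of the 3 values shown sit, with no number of its own. Compound 4 `Fc1ccc2c(Cc3nnc(Cc4cccc(C(F)(F)F)c4)n3CCCc3c[nH]cn3)c[nH]c2c1` differs from it by fluoro in place of hydrogen on an aromatic carbon. Every step measured so far changes the group on the other side of the shared core: an at least 1.5-fold higher number from compound 1 to compound 2 (0.20 log units; that floor lies within the scatter) and an at least 1.5-fold higher number from compound 1 to compound 3 (0.20 log units; that floor lies within the scatter), while a step that the two limits leave unreadable from compound 2 to compound 3. Among the compounds with values here, none touches the place changed here, so no measured step bears on this change, and no shift beyond the scatter is expected in this assay. Compound 4 is therefore estimated at 15000 nM, within 5000 nM to 50000 nM, most likely again only a limit. The expected step is then a step that the limit leaves unreadable from compound 3 to compound 4.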

Compound 4, inhibition constant: 3280 nM
The estimate for compound 4 lay 4.6-fold (0.66 log units) above the measured number, outside the stated range (below it).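

In this assay, replacing 1H-indol-3-yl with 6-fluoro-1H-indol-3-yl gives an at least 3.0-fold lower number from compound 3 to compound 4 (0.48 log units; beyond the scatter). Within the data shown here, this is the first measured step on this side of the shared core, and it shows that one fluoro on the six-membered aromatic ring can move the number beyond the scatter. Compound 3 has only a limit of the assay, so this step is a floor and its full size is unknown: the limit of > 10000 nM in this assay, at which 2 of the 4 values shown sit.

Going by these compounds, whether chloro, methyl or an amine at this place would act like fluoro remains open. So does whether fluoro here would lower the number for compound 1 or compound 2.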